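This account rests on a few compounds, and the source may have more. Where it says the series, first, only, none or still open, it means among the compounds named here.

In a functional assay on MGC-803 cells (Homo sapiens) for inhibition, read by MTT assay, with a stated time of 72 h (on this read-out higher numbers stand for weaker inhibition and lower numbers for stronger inhibition), three compounds sharing one core have been measured, differing only in the group on a saturated chain carbon bound to a sulfur. Compound 1 `Cc1cc(N2CC[C@@H](C)[C@@H](N(C)c3ncnc4[nH]ccc34)C2)n2nc(SCc3nc4ccccc4[nH]3)nc2n1`, which carries 1H-benzimidazol-2-yl there, gives 21200 nM. Compound 2 `Cc1cc(N2CC[C@@H](C)[C@@H](N(C)c3ncnc4[nH]ccc34)C2)n2nc(SCc3csc4ccc(Cl)cc34)nc2n1`, which carries 5-chloro-1-benzothiophen-3-yl, gives > 100000 nM, and this is a limit of the assay, not a number. Compound 3 `Cc1cc(N2CC[C@@H](C)[C@@H](N(C)c3ncnc4[nH]ccc34)C2)n2nc(SCC3CCCCC3)nc2n1`, which carries cyclohexyl, gives 9170 nM, the lower of the two actual numbers.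

Compound 4 `Cc1cc(N2CC[C@@H](C)[C@@H](N(C)c3ncnc4[nH]ccc34)C2)n2nc(SCc3ccc(F)c(Cl)c3)nc2n1` has 3-chloro-4-fluorophenyl in place of cyclohexyl on a saturated chain carbon bound to a sulfur. Among the measured compounds shown here, two measured steps bear on this change, as each arrives at cyclohexyl from an aromatic group. They are a 2.3-fold lower number from compound 1 to compound 3 (0.36 log units; beyond the scatter), which is modest, and an at least 10-fold lower number from compound 2 to compound 3 (1.03 log units; beyond the scatter), which is large. Both point the same way, so leaving cyclohexyl for an aromatic group is expected to raise the number, though two steps are thin support. The expected step is a 2.2-fold higher number from compound 3 to compound 4 (0.34 log units; beyond the scatter). For compound 4 the estimated value is 20000 nM, with an expected range from 7000 nM to 80000 nM.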

Compound 4, half-maximal inhibitory concentration: 52000 nM
Beside the measured number, compound 4's estimate is 2.6-fold (0.41 log units) below it, and the stated range covers the measured number.
By their numbers in this assay, from the lowest: compound 3; then compound 1; then compound 4. At a limit, above all of these: compound 2.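

In this assay, 3-chloro-4-fluorophenyl in place of cyclohexyl gives a 5.7-fold higher number from compound 3 to compound 4 (0.75 log units; beyond the scatter), so a third aromatic group also ends up weaker than cyclohexyl, and compound 3 remains the strongest of the four. Aromatic groups also differ from one another at this position: 3-chloro-4-fluorophenyl in place of 1H-benzimidazol-2-yl gives a 2.5-fold higher number from compound 1 to compound 4 (0.39 log units; beyond the scatter). 3-chloro-4-fluorophenyl in place of 5-chloro-1-benzothiophen-3-yl gives an at least 1.9-fold lower number from compound 2 to compound 4 (0.28 log units; that floor lies within the scatter) and that floor lies within the scatter, so these two groups cannot be put in order. The value of compound 2 is a limit and not a number: the limit of > 100000 nM in this assay, at which 1 of the 4 values shown sits.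

The compounds shown leave open whether an unsubstituted phenyl would sit closer to compound 3 or compound 4, and so what the chlorine and fluorine contribute. They also leave open whether a cyclopentyl ring, a straight hexyl chain or an amine on the cyclohexyl ring would give a lower number than compound 3.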